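Swapping chloro for nitro on the lead compound

A few compounds are considered here, and "the series" means these few. Any claim that something is new, unique, unknown or untested is made for them only; others in the source may bear on it.

So far three compounds have numbers in a functional assay on HUVEC cells (Homo sapiens) for inhibition, with a stated time of 4 days; a higher number here means a weaker inhibitor, a lower number a stronger inhibitor. Compound 1 `COc1ccc(C(C)=O)cc1COc1ccc(Cl)cc1` gives 1200 nM, and compound 2 `Cc1cc(OCc2cccc(C#N)c2)ccc1Cl` gives 11000 nM. Compound 3 `COc1ccc(C(N)=O)cc1/C=C/c1ccc(Cl)cc1` gives 87 nM, the lowest of the three numbers, and its gaps to compound 1 and compound 2 both lie beyond the scatter of repeated measurements. This makes compound 3 the strongest inhibitor of the set.

Compound 4 `COc1ccc(C(N)=O)cc1/C=C/c1ccc([N+](=O)[O-])cc1` changes it in one place, with nitro in place of chloro on an aromatic carbon, para to a large group (nitro in place of chloro on an aromatic carbon). Among the compounds with values here, no measured pair of compounds shows this swap, so the expectation rests on compound 3 at 87 nM and has to stay broad. A small move towards a higher number is expected in this assay, an estimated step of a 1.7-fold higher number from compound 3 to compound 4 (0.24 log units; within the scatter). Compound 4 is expected near 150 nM, with an estimated range from 35 nM to 700 nM.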

Compound 4, half-maximal inhibitory concentration: 4700 nM
Compound 4: middle estimate off by 31-fold (1.50 log units), on the low side; measured number outside the range, above it.
By their numbers in this assay, from the lowest: compound 3; then compound 1; then compound 4; then compound 2.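

In this assay, replacing chloro with nitro gives a 54-fold higher number from compound 3 to compound 4 (1.73 log units; beyond the scatter), so this place on the aromatic ring, para to a large group, is far from indifferent to what sits on it. Within the data shown here, this single change, with the rest of the molecule held constant, is enough to separate the two compounds by well beyond the scatter, something the earlier compounds, which differ from each other in more than one place, could not show. Nothing measured here explains the loss, which comes with three heavy atoms replacing one and two hydrogen-bond acceptors arriving.

The compounds shown leave open which of these differences matters. Methyl, bromo or an amine at the same place would help to show whether chloro is unusually good here or nitro unusually poor.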